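The source may hold more compounds than are shown below. What is called first, only, known or untested is meant among the compounds shown, and "the series" means these compounds.

Measured in a functional assay on the whole organism for antagonist activity, with Rattus norvegicus as the target; on this read-out higher numbers stand for an effect only at larger amounts of compound and lower numbers for an effect already at smaller amounts:
- compound 1 `c1ccc2c(c1)CCC2CCCN1CCN(c2cccc3c2OCCO3)CC1` – 0.29 mg/kg
- compound 2 `c1ccc2c(c1)CC(CCN1CCN(c3cccc4c3OCCO4)CC1)C2` – 0.27 mg/kg
- compound 3 `C1=C(CCN2CCN(c3cccc4c3OCCO4)CC2)c2ccccc2CC1` – 0.4 mg/kg

Compound 2 at 0.27 mg/kg lies within the usual scatter of compound 1 and of compound 3, so no order can be read among these three numbers.

Compound 4 `Clc1cccc2c1CC2CCN1CCN(c2cccc3c2OCCO3)CC1` has not yet been measured. Its structure differs from compound 2 in one group: a group of 9 heavy atoms (8 carbon, 1 chlorine; one four-membered non-aromatic ring of carbon only, one six-membered aromatic ring of carbon only) in place of a group of 9 heavy atoms (9 carbon; one five-membered non-aromatic ring of carbon only, one six-membered aromatic ring of carbon only), on a saturated chain carbon, two bonds along the chain from an amine nitrogen in a ring (the rest of the molecule stays the same).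

Going by the values given here, no measured pair shows what such a swap does in this assay and no measured compound carries chlorine or a four-membered ring, so any forecast is uncertain. The three measured compounds differ in structure yet stay close together, with compound 1 at 0.29 mg/kg and compound 3 at 0.4 mg/kg in this group. No step beyond the scatter is therefore expected, only a slight lean toward a higher number. The expected change is a 1.5-fold higher number from compound 2 to compound 4 (0.17 log units; within the scatter) and would be a small one. For compound 4 the estimated value is 0.4 mg/kg with an expected range from 0.15 mg/kg to 1.2 mg/kg in repeat measurements.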

Compound 4, dose for 50% inhibition: 1.13 mg/kg
Compound 4: the middle estimate sits 2.8-fold (0.45 log units) below what was measured; the measured number falls inside the stated range.
By their numbers in this assay, from the lowest: compounds 2, 1 and 3 (each within the scatter of the next); then compound 4.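

In this assay, the group on the saturated chain carbon, two bonds along the chain from the ring amine nitrogen, turns out to matter: the swap gives a 4.2-fold higher number from compound 2 to compound 4 (0.62 log units; beyond the scatter), so more compound is needed for the same effect. Going by these compounds alone, the three earlier numbers allowed no order, and this is the first step here that stands beyond the scatter. Nothing measured on these compounds explains the step.

The swap shrinks the non-aromatic ring and brings in chlorine at once, so the compounds shown do not tell which of the two changes carries the step. Also open, from the compounds shown here alone, is whether a fluorine atom or a methoxy group in place of the chlorine, or the four-membered ring with no chlorine at all, would give a number closer to that of compound 2.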